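A few compounds are considered here, and "the series" means these few. Any claim that something is new, unique, unknown or untested is made for them only; others in the source may bear on it.

Three compounds share one core and differ only in the ring carried on an aromatic carbon. Compound 1 `COc1nc(N)nc2c1c(-c1ccco1)cn2[C@@H]1O[C@H](CO)[C@@H](O)[C@H]1O` bears furan-2-yl, and in a functional assay on CEM-DNR-bulk cells (Homo sapiens), read by MTT assay, with a stated time of 72 h (a lower number here means a stronger inhibitor, a higher number a weaker inhibitor), compound 1 gives > 20000 nM, a limit of the assay and not a number. Compound 2 `COc1nc(N)nc2c1c(-c1ccoc1)cn2[C@@H]1O[C@H](CO)[C@@H](O)[C@H]1O` bears furan-3-yl and gives > 20000 nM, again a limit. Compound 3 `COc1nc(N)nc2c1c(-c1ccsc1)cn2[C@@H]1O[C@H](CO)[C@@H](O)[C@H]1O` bears thiophen-3-yl and gives > 20000 nM, also a limit. Compound 3 thus has no number of its own and stands with the other two: the limit of > 20000 nM in this assay, at which 3 of the 3 values shown sit.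

Compound 4 `C#Cc1cn([C@@H]2O[C@H](CO)[C@@H](O)[C@H]2O)c2nc(N)nc(OC)c12` carries ethynyl in place of thiophen-3-yl on an aromatic carbon. Within the data shown here, three measured steps bear on this change: a step that the two limits leave unreadable from compound 1 to compound 2, a step that the two limits leave unreadable from compound 1 to compound 3 and a step that the two limits leave unreadable from compound 2 to compound 3. None of them has a readable size, and all three only exchange one ring for another, whereas compound 4 has no ring at this place. They therefore offer only a weak guide, and the expectation starts from the limit of compound 3 in this assay. A modest move toward stronger inhibition is expected, as an at least 1.3-fold lower number from compound 3 to compound 4 (0.12 log units; that floor lies within the scatter), though compound 4 may well stay at the limit. For compound 4 the estimated value is 15000 nM, with an expected range from 2000 nM to 20000 nM.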

Compound 4, half-maximal inhibitory concentration: > 20000 nM
Compound 4 ended at the assay's limit; the forecaster's own chance of this, stated with the estimate: 65%; middle value at least 1.3-fold (0.12 log units) away from the limit.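

Compound 4 stays at a limit and not a number, as do compound 1, compound 2 and compound 3, so none of the steps from those three to compound 4 can be read in this assay: the limit of > 20000 nM in this assay, at which 4 of the 4 values shown sit.

The compounds shown leave open how strongly any of the four inhibits, and whether any group at this place on the shared core would give a measurable value.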